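Notes on compound 2 to compound 4

A few compounds are considered here, and "the series" means these few. Any claim that something is new, unique, unknown or untested is made for them only; others in the source may bear on it.

Measured so far in a functional assay on Bel-7402 cells (Homo sapiens) for antiproliferative activity, with a stated time of 72 h; on this read-out higher numbers stand for weaker inhibition and lower numbers for stronger inhibition

- compound 1 `COc1cc(OC)c(C(=O)/C=C/c2ccccc2Cl)c(O)c1CN1CCCC1` gives 6800 nM
- compound 2 `COc1cc(OC)c(C(=O)/C=C/c2ccccc2Cl)c(O)c1CN(C)CC(=O)O` gives 35200 nM
- compound 3 `COc1cc(O)c2c(=O)cc(-c3ccccc3Cl)oc2c1CN1CCCCC1` gives 118000 nM

Compound 2 stands second highest of the three numbers. Compound 3 lies above it and compound 1 below it, and both gaps are beyond the scatter.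

The next entry is compound 4 `COc1cc(OC)c(C(=O)/C=C/c2ccccc2Cl)c(O)c1CN(C)C`, which has not yet been measured. Against compound 2 the change is hydrogen in place of carboxy on a saturated chain carbon bound to an amine nitrogen. This is hydrogen in place of carboxy on a saturated chain carbon bound to an amine nitrogen, so (carboxymethyl)(methyl)amino becomes dimethylamino.

Going by the values given here, one measured step bears on this: a 5.2-fold higher number from compound 1 to compound 2 (0.71 log units; beyond the scatter). That step is modest, and it goes from a carboxy-free amine to the carboxymethyl amine. Compound 4 also lacks the carboxy group, so a move back toward lower numbers in this assay is expected, of similar size and beyond the scatter. This rests on a single step, and dimethylamino and pyrrolidin-1-yl have not been compared directly.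

The expected change is a 3.9-fold lower number from compound 2 to compound 4 (0.59 log units; beyond the scatter) in this estimate. For compound 4 the estimated value is 9000 nM with an expected range from 3500 nM to 25000 nM in this read-out.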

Compound 4, half-maximal inhibitory concentration: 21800 nM
Estimate against measurement, compound 4: 2.4-fold (0.38 log units) below, and the stated range covers the measured number.
By their numbers in this assay, from the lowest: compound 1; then compounds 4 and 2 (each within the scatter of the next); then compound 3.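

In this assay, hydrogen in place of carboxy on a saturated chain carbon bound to an amine nitrogen gives a 1.6-fold lower number from compound 2 to compound 4 (0.21 log units; within the scatter), so this pair offers no readable effect of the carboxy group on its own. The gap between compound 1 and compound 2 therefore cannot be assigned to the carboxy group alone, since dimethylamino in place of pyrrolidin-1-yl, with no carboxy group on either side, already gives a 3.2-fold higher number from compound 1 to compound 4 (0.51 log units; beyond the scatter) and shows that the amine itself matters at this position. Nothing at hand bears on why the steps take these sizes.

On these data alone, it remains open whether a methyl ester in place of the carboxy group, a longer chain such as carboxyethyl on the nitrogen, or a morpholin-4-yl group would lie with compound 1 or with compound 4 and compound 2. The series also leaves open whether the step from dimethylamino to pyrrolidin-1-yl would carry over to the core of compound 3, which differs from the other compounds in more than one place.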